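The source may report more compounds than this note shows. Statements on the series, on what has been measured and on what is new or still open speak of the compounds shown alone.

Of the compounds shown here, two have been measured in an ADME assay (Rattus norvegicus, strain Han-wistar) for pharmacokinetics, at a dose of 1.5 umol/kg by the intravenous route; on this read-out higher numbers stand for fast clearance and lower numbers for slow clearance. Compound 1 `CC(C)n1cc(-c2ccnc3[nH]c(C4CCN(CC(=O)N5CCCC5)CC4)cc23)ccc1=O` gives 91 mL/min/kg, the highest of the two numbers. Among the compounds with values here, compound 2 `COc1cc(C(=O)N2CCCC2)ccc1-c1ccnc2[nH]c(C3CCNCC3)cc12` gives 17 mL/min/kg, a lower number that lies beyond the scatter; the two compounds differ in more than one place, so their two values show only that compound 1 is cleared faster than compound 2. Compound 3 `CC(C)n1cc(-c2ccnc3[nH]c(C4CCN(Cc5cccs5)CC4)cc23)ccc1=O` has not yet been measured. It keeps the core of compound 1 and changes one group: thiophen-2-yl in place of (pyrrolidin-1-yl)carbonyl on a saturated chain carbon bound to an amine nitrogen in a ring. The (pyrrolidin-1-yl)carbonyl leaves and thiophen-2-yl enters on the saturated chain carbon bound to the amine nitrogen in the ring. Within the data shown here, no measured pair in this set shares this change, so there is no step to lean on. Compound 1 already shows fast clearance in this assay, and nothing measured here points to the new group moving that number either way. The step of a 1.0-fold lower number from compound 1 to compound 3 (0.00 log units; within the scatter) is expected to stay within the scatter. For compound 3 the estimate in this assay is 90 mL/min/kg, with a range from 50 mL/min/kg to 160 mL/min/kg.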

Compound 3, clearance: 92 mL/min/kg
Compound 3: the middle estimate sits 1.0-fold (0.01 log units) below what was measured; measured number inside the range.
By their numbers in this assay, from the lowest: compound 2; then compounds 1 and 3 (each within the scatter of the next).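

In this assay, placing thiophen-2-yl instead of (pyrrolidin-1-yl)carbonyl on the saturated chain carbon bound to an amine nitrogen in a ring gives a 1.0-fold higher number from compound 1 to compound 3 (0.00 log units; within the scatter), so the two compounds cannot be told apart on this read-out. Within the data shown here, this is the first direct reading at this position: the change removes the carbonyl and the amide nitrogen and exchanges a five-membered non-aromatic ring for a five-membered aromatic ring holding sulfur, yet clearance stays fast with either group. Nothing available gives a reason why the two groups read alike, so the match stands as an observation without an explanation.

Whether this position can shift clearance at all remains open, since both groups shown are five-membered rings, and a carboxylic acid, a hydroxyethyl chain or a plain methyl on the ring amine nitrogen could give a different number. Also open, from the compounds shown here alone, is whether these two groups would read alike on a core other than that of compound 1.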